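A few compounds are considered here, and "the series" means these few. Any claim that something is new, unique, unknown or untested is made for them only; others in the source may bear on it.

Compound 1 `C=C1[C@@H](OC(C)=O)C[C@@H]2[C@](C)(COC=O)[C@H](OC(C)=O)CC[C@@]2(C)[C@@H]1C[C@@H](Nc1ccccc1C(=O)O)C1=CCOC1=O`: 42500 nM
Compound 2 `C=C1[C@@H](OC(C)=O)C[C@@H]2[C@](C)(CO[Si](C)(C)C(C)(C)C)[C@H](OC(C)=O)CC[C@@]2(C)[C@@H]1C[C@@H](Nc1ccccc1C(=O)O)C1=CCOC1=O`: 6050 nM
Compound 3 `C=C1[C@@H](OC(C)=O)C[C@@H]2[C@](C)(COC=O)[C@H](OC(C)=O)CC[C@@]2(C)[C@@H]1C[C@@H](Nc1ccc(C(=O)O)cc1)C1=CCOC1=O`: > 50000 nM (a limit of the assay, not a number)

In a functional assay on KB cells (Homo sapiens) for cytotoxicity, read by sulforhodamine B assay (a higher number here means a weaker inhibitor, a lower number a stronger inhibitor), compound 2 gives 6050 nM, the lower of the two exact numbers. The measured step leading to it is a 7.0-fold lower number from compound 1 to compound 2 (0.85 log units; beyond the scatter), made at an oxygen on a saturated carbon and not at the aryl group.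

Compound 4 `C=C1[C@@H](OC(C)=O)C[C@@H]2[C@](C)(CO[Si](C)(C)C(C)(C)C)[C@H](OC(C)=O)CC[C@@]2(C)[C@@H]1C[C@@H](Nc1cccc2ccccc12)C1=CCOC1=O` keeps the rest of compound 2 and differs at one place: naphthalen-1-yl in place of 2-carboxyphenyl on an amine nitrogen. Among the measured compounds shown here, only one measured step touches that aryl group, an at least 1.1-fold higher number from compound 1 to compound 3 (0.07 log units; that floor lies within the scatter), and it offers a floor rather than a size. For the measured compounds named here, no measured compound lacks the carboxyphenyl group, so the data give only weak guidance for this exchange. The expected step in this assay is therefore small and not clearly beyond the scatter, leaning slightly towards a lower number: a 1.7-fold lower number from compound 2 to compound 4 (0.24 log units; within the scatter). Compound 4 is estimated at 3500 nM, with an expected range of 1000 nM to 12000 nM.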

Compound 4, half-maximal inhibitory concentration: 8930 nM
Compound 4: middle estimate off by 2.6-fold (0.41 log units), on the low side; measured number inside the range.
By their numbers in this assay, from the lowest: compounds 2 and 4 (each within the scatter of the next); then compound 1. At a limit, above all of these: compound 3.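

In this assay, among the compounds shown here, exchanging 2-carboxyphenyl for naphthalen-1-yl on the amine nitrogen gives a 1.5-fold higher number from compound 2 to compound 4 (0.17 log units; within the scatter), the first step at this position that reads as a size and not merely as a floor. With the silyl ether of compound 2 kept in place, the carboxylic acid on the aryl group can therefore give way to a second aromatic ring of carbon only, with no hydrogen-bond donor or acceptor, and the change stays within the scatter. Nothing measured here accounts for this outcome.

On these data alone, it remains open whether the same exchange would hold on the formate ester of compound 1. Also open, as far as these compounds go, is whether a plain phenyl, a naphthalen-2-yl or an aryl group carrying an amine on this nitrogen would move the number beyond the scatter.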